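A few compounds are considered here, and "the series" means these few. Any claim that something is new, unique, unknown or untested is made for them only; others in the source may bear on it.

Working notes on the series. In an assay on BaF3 cells for inhibition of proto-oncogene tyrosine-protein kinase receptor Ret (Homo sapiens), read by MTT assay, with a stated time of 48 h (on this read-out lower numbers stand for stronger inhibition of growth and higher numbers for weaker inhibition of growth), compound 1 `CC(C)n1nc(-c2cc(C3CCCCC3)on2)c2c(N)ncnc21` gives 9500 nM, the highest of the two numbers shown. The nearest number is that of compound 2 `CC(C)(O)Cn1nc(-c2cc(C3CC3)on2)c2c(N)ncnc21`, which in this assay gives 1770 nM. Compound 3 `CCCCCCCn1nc(-c2cc(C3CC3)on2)c2c(N)ncnc21` sits at a limit of this assay, > 10000 nM, and is not a number. Going by the values given here, the one step that can be sized, an at least 5.6-fold higher number from compound 2 to compound 3 (0.75 log units; beyond the scatter), concerns only the chain on the aromatic nitrogen of the shared core, and it runs into (the limit of > 10000 nM in this assay, at which 1 of the 3 values shown sits).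

Compound 4 `CC(C)n1nc(-c2cc(-c3ccc(F)cc3)on2)c2c(N)ncnc21` differs from compound 1 by 4-fluorophenyl in place of cyclohexyl on an aromatic carbon. Among the compounds with values here, none of the measured steps touches the group on the aromatic carbon of the five-membered ring; every measured change sits on the chain bound to the aromatic nitrogen, so no measured step bears directly on this change. The expected step in this assay, a 1.6-fold lower number from compound 1 to compound 4 (0.20 log units; within the scatter), is therefore held near no change beyond the scatter, with a wide range. Compound 4 is estimated at 6000 nM in this assay, with a range from 1200 nM to 20000 nM expected.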

Compound 4, concentration for 50% growth inhibition: > 10000 nM
Compound 4 was reported as a limit (the forecaster's own chance of this, stated with the estimate: 30%); middle value at least 1.6-fold (0.22 log units) away from the limit.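

In this assay compound 4 gives > 10000 nM, which is a limit and not a number. Going by these compounds alone, this is the first reading on the aromatic carbon next to the ring oxygen, and it shows that 4-fluorophenyl in place of cyclohexyl brings no lower number here, with the step reading an at least 1.0-fold higher number from compound 1 to compound 4 (0.02 log units; that floor lies within the scatter), so no change beyond the scatter is established and its true size stays unknown. The step has only a floor because compound 4 joins compound 3 at the top of the measurable range: the limit of > 10000 nM in this assay, at which 2 of the 4 values shown sit.

Open, on these data alone, is how an amine or a carboxylic acid on this aromatic carbon would read in this assay. Within the data shown here, also open is whether 4-fluorophenyl and cyclohexyl would separate on the shared core when the chain on the aromatic nitrogen is the one carried by compound 2.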